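A few compounds are considered here, and "the series" means these few. Any claim that something is new, unique, unknown or untested is made for them only; others in the source may bear on it.

Measured compounds:
Compound 1 `COc1ccc(-c2cc3cccc(OC)c3nc2O)cc1` in a functional assay on A549 cells (Homo sapiens) for cytotoxicity, read by colorimetric assay and MTT assay (a higher number here means a weaker inhibitor, a lower number a stronger inhibitor), gives 10000 nM.
Compound 2 `COc1ccc(-c2cc3c(OC)cc(OC)cc3n(C)c2=O)cc1` in this assay gives 10000 nM.

Compound 2 stands level with compound 1 at the digits shown; the two values are within the scatter of each other, so no ordering between compound 1 and compound 2 can be drawn from them. Both sit at the same weak end of the range covered so far.

Compound 3 `CCN(CC)C(=O)Cn1c(=O)c(-c2ccc(OC)cc2)cc2c(OC)cc(OC)cc21` is not yet measured in this assay. Relative to compound 2 it carries diethylcarbamoyl in place of hydrogen on a saturated chain carbon bound to an aromatic nitrogen. Within the data shown here, the two measured compounds differ from each other in several places at once, so no single step is available to calibrate how a change of this kind moves the read-out. With nothing in the measured pair pointing toward a gain or a loss, the expected step of no change at the digits printed from compound 2 to compound 3 (within the scatter) from compound 2 to compound 3 is taken as none beyond the scatter. Compound 3 is therefore estimated to give 10000 nM in this assay, with a range of 4000 nM to 25000 nM; the measurement will show whether it departs from compound 2.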

Compound 3, half-maximal inhibitory concentration: 10000 nM
Estimate against measurement, compound 3: no gap at the digits printed; low and high end bracket the measured number.
By their numbers in this assay, from the lowest: compounds 1, 2 and 3 (each within the scatter of the next).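

In this assay, the series now has its first step that changes only one place: no change at the digits printed from compound 2 to compound 3 (within the scatter), with diethylcarbamoyl in place of hydrogen on a saturated chain carbon bound to an aromatic nitrogen. Read one bond further out, this is methyl to (diethylcarbamoyl)methyl, so this place carries the full amide-bearing group with no movement in the read-out beyond the scatter, which compounds 1 and 2, differing in several places at once, could not show. No supporting measurement bears on why the read-out holds at this place.

Still open, as far as these compounds go, is whether a different group at this place, such as an amine, a carboxylic acid or a longer chain, would move the read-out away from the level of compound 3 at 10000 nM. A single step also cannot say whether the same diethylcarbamoyl change would behave alike on another member of the series, or whether a replacement of a methoxy group on the shared core by hydroxy or chloro would shift the value.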